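The compounds below may be only part of what the source reports. "The series", "measured", "known", "first", "only" and "open" are said of these compounds alone.

Compound 1 `CCOC(=O)c1[nH]c2ccccc2c1/C=N\NC(=O)c1ccncc1` is the reference point of this small set. In an ADME assay on cells (Peritoneal macrophage cell, Mus musculus, strain C57BL/6) for cytotoxicity, read by LDH release (on this read-out lower numbers stand for stronger inhibition and higher numbers for weaker inhibition), compound 1 gives 16 ug/mL, which places it second highest of the three numbers recorded; its nearest neighbour is compound 3, its furthest compound 2, and both lie within the scatter of it. Compound 2 `CCOC(=O)c1[nH]c2ccccc2c1/C=N\NC(=O)c1cc[n+]([O-])cc1` gives 18 ug/mL in this assay, and compound 3 `CCOC(=O)c1[nH]c2ccc(C)cc2c1/C=N\NC(=O)c1ccncc1` gives 15 ug/mL in this assay. The two measured steps are small: a 1.1-fold higher number from compound 1 to compound 2 (0.05 log units; within the scatter) and a 1.1-fold lower number from compound 1 to compound 3 (0.03 log units; within the scatter).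

The unmeasured compound 4 `O=C(N/N=C\c1c[nH]c2ccccc12)c1ccncc1` differs from compound 1 by a change at a different place on the shared core: hydrogen in place of ethoxycarbonyl on an aromatic carbon. The ethoxycarbonyl leaves from an aromatic carbon of the five-membered aromatic ring with one nitrogen, part of the fused system of two rings. Going by the values given here, neither measured step touches that part of the molecule, so no step bears directly on this change; what the set does show is that the two changes tried so far, on the carbonyl carbon and on an aromatic carbon of the other ring, each stayed within the scatter. On that basis the step is expected to be no change at the digits printed from compound 1 to compound 4 (within the scatter), with no change beyond the scatter. Compound 4 is therefore estimated at 16 ug/mL in this assay, expected to fall between 8 ug/mL and 32 ug/mL.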

Compound 4, half-maximal inhibitory concentration: 40 ug/mL
Estimate against measurement, compound 4: 2.5-fold (0.40 log units) below; measured number above the stated range.
By their numbers in this assay, from the lowest: compounds 3, 1 and 2 (each within the scatter of the next); then compound 4.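

In this assay, going by these compounds alone, replacing the ethoxycarbonyl with hydrogen gives a 2.5-fold higher number from compound 1 to compound 4 (0.40 log units; beyond the scatter) and is the only step in this set that lies beyond the scatter, with the higher number standing for weaker inhibition on this read-out. Within the data shown here, the aromatic carbon of the five-membered aromatic ring, next to the ring nitrogen, is thus the one place so far where a change moves the number beyond the scatter, whereas the changes on the carbonyl carbon and on an aromatic carbon of the other ring stayed within it. The step is modest and rests on this single pair of compounds, and nothing available explains why the number moves.

The compounds shown leave open whether the whole ethoxycarbonyl matters or whether other groups at this place, such as a carboxylic acid, a methyl ester or a plain methyl, would keep the number close to that of compound 1. They also leave open whether the two small changes elsewhere would stay within the scatter on the core of compound 4, without the ethoxycarbonyl.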